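Hydroxy to Methoxy: A Step Without Direct Precedent

A few compounds are considered here, and "the series" means these few. Any claim that something is new, unique, unknown or untested is made for them only; others in the source may bear on it.

Compound 2 `O=C(Nc1cccc(-n2cc(-c3ccncc3)c(-c3cc(O)cc(Cl)c3)n2)c1)Nc1ccc(Cl)c(Cl)c1` gives 59% in a functional assay on MDA-MB-468 cells (Homo sapiens) for inhibition, read by sulforhodamine B assay, with a stated time of 48 h, tested at 1 uM (a higher number here means a weaker effect of the compound at the concentration tested, a lower number a stronger effect), the second highest of the three numbers measured. For the measured compounds named here, its nearest neighbour is compound 1 `O=C(Nc1cccc(-n2cc(-c3ccncc3)c(-c3cc(O)cc(Cl)c3)n2)c1)Nc1ccc(Cl)c(C(F)(F)F)c1`, which gives 75%; the step of a number 16 percentage points lower from compound 1 to compound 2 (beyond the scatter) is the only single-point change measured and sets the scale for a modest effect. Compound 3 `COc1cc(Cl)cc(-c2nn(-c3cccc(NC(=O)Nc4cc(C(F)(F)F)cc(C(F)(F)F)c4)c3)cc2-c2ccncc2)c1` gives 15%, but it differs from compound 2 in two places, so its value alone cannot be assigned to either change. Compound 4 `COc1cc(Cl)cc(-c2nn(-c3cccc(NC(=O)Nc4ccc(Cl)c(Cl)c4)c3)cc2-c2ccncc2)c1` makes only one of them: methyl in place of hydrogen on an oxygen on an aromatic ring. Going by the values given here, no measured step bears on hydroxy to methoxy alone. The low value of compound 3 at 15% suggests some drop. Compound 4 is therefore expected to move by a number 14 percentage points lower from compound 2 to compound 4 (beyond the scatter) in this assay. The estimate for compound 4 is 45%, between 20% and 70%.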

Compound 4, a percentage reported as activity, at one concentration (the size of the read-out at that concentration, not a potency): 69%
For compound 4 the middle estimate is 24 percentage points below the measured one; low and high end bracket the measured number.
By their numbers in this assay, from the lowest: compound 3; then compounds 2, 4 and 1 (each within the scatter of the next, the first and the last beyond it).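

Measured on its own in this assay, hydroxy to methoxy on the 3-chloro-5-hydroxyphenyl group gives a number 10 percentage points higher from compound 2 to compound 4 (within the scatter) and so stays within the scatter. With this partner, then, the hydrogen on this oxygen can give way to methyl without a change that this read-out can separate. Nothing shown here offers a measured explanation for this result. From the compounds shown here alone, whether an ethoxy group or a longer chain on this oxygen, or an amine in place of the hydroxy group, would read the same stays open. So does whether methoxy behaves alike with the trifluoromethyl partner of compound 1.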